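This account rests on a few compounds, and the source may have more. Where it says the series, first, only, none or still open, it means among the compounds named here.

Working notes on the series. Among the measured compounds shown here, compound 1 `COc1ccc(F)c(-c2ccc3c(NC(=O)c4ccc(N(C)CCN(C)C)cc4)n[nH]c3c2)c1F` is the only member with a resolved number in a functional assay on SNU-16 cells (Homo sapiens) for antiproliferative activity, read by CCK-8 assay, with a stated time of 72 h (on this read-out higher numbers stand for weaker inhibition and lower numbers for stronger inhibition), where compound 1 gives 366 nM. Compound 2 `CCN1CCN(c2ccc(C(=O)Nc3n[nH]c4cc(-c5cccc(OC)c5F)cc(F)c34)cc2)CC1` reaches only the limit of the assay, and in this assay compound 2 is recorded as > 1000 nM. Compound 3 `COc1cccc(-c2ccc3c(NC(=O)c4ccc(N5CCN(C)CC5)c(F)c4)n[nH]c3c2)c1F` likewise ends at a limit, and in this assay compound 3 shows > 1000 nM. For the measured compounds named here, compound 1 therefore stands as the single measured value, the two others sitting at the limit of > 1000 nM in this assay, at which 2 of the 3 values shown sit.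

Compound 4 `COc1ccc(F)c(-c2ccc3c(NC(=O)c4ccc(N5C[C@@H](C)N[C@@H](C)C5)cc4)n[nH]c3c2)c1F` is not yet measured. It is derived from compound 1 by 3,5-dimethylpiperazin-1-yl in place of (2-(dimethylamino)ethyl)(methyl)amino on an aromatic carbon, in words 3,5-dimethylpiperazin-1-yl in place of (2-(dimethylamino)ethyl)(methyl)amino on an aromatic carbon. Going by the values given here, no pair of measured compounds differs in a single place, so the size of this step is not fixed by any measured comparison. Compounds 2 and 3 both sit at the limit but differ from compound 1 in more than one place, so their values show only that limits occur in this set.

The expected change in this assay is a moderate weakening from compound 1 to compound 4, a 1.9-fold higher number from compound 1 to compound 4 (0.28 log units; within the scatter), beyond the usual scatter but not certainly so, with a real chance that only a limit is returned. Compound 4 is estimated in this assay at 700 nM, with a range of 250 nM to 2000 nM.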

Compound 4, half-maximal inhibitory concentration: 582 nM
Estimate against measurement, compound 4: 1.2-fold (0.08 log units) above; the measured number falls inside the stated range.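

Working notes, continued. In this assay, among the compounds shown here, the exchange of (2-(dimethylamino)ethyl)(methyl)amino for 3,5-dimethylpiperazin-1-yl, on an aromatic carbon para to a large group, gives a 1.6-fold higher number from compound 1 to compound 4 (0.20 log units; within the scatter), the first comparison that differs in one place, and it does not tell the two compounds apart. For this pair, a group with no ring and 0 hydrogen-bond donors and a six-membered non-aromatic ring with 1 hydrogen-bond donor and 2 defined stereocentres are therefore interchangeable at this position within the scatter. Compound 4 returns a resolved number and not a limit, so this change does not carry the series to the limit of the assay, which remains confined to the other compounds: the limit of > 1000 nM in this assay, at which 2 of the 4 values shown sit.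

Going by these compounds, whether a piperazine without the two methyl groups, a morpholine or a longer chain ending in a dimethylamino group would stay within the scatter at this position remains open. Compounds 2 and 3 differ from compound 1 in more than one place, so what separates their limits from the resolved values cannot be assigned to any single group.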